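The source may report more compounds than this note shows. Statements on the series, on what has been measured and on what is new or still open speak of the compounds shown alone.

Measured in a functional assay on P388 cells (Mus musculus) for inhibition; a lower number here means a stronger inhibitor, a higher number a weaker inhibitor:
- compound 1 `C(=C\c1ccc2[nH]ccc2c1)\c1ccc2ccccc2c1`: > 5000 nM
- compound 2 `Cn1ccc2cc(/C=C/c3ccc4ccccc4c3)ccc21`: > 5000 nM

Compound 2 gives > 5000 nM, which is a limit of the assay and not a number. For the measured compounds named here, the series so far stands at the limit of > 5000 nM in this assay, at which 2 of the 2 values shown sit, so no measured potency exists as a reference point.

Compound 3 `Cn1ccc2cc(/C=C\c3ccc4ccccc4c3)ccc21` comes from compound 2 through a single change: the two compounds have the same atoms and bonds and differ only in configuration as drawn: 1 of 1 stereo elements differ; a double bond is drawn E in compound 2 and Z in compound 3.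

Going by the values given here, no measured step shows what this change does in this assay, so the expectation carries wide uncertainty. A modest gain in inhibition is expected, though the result may well stay at the limit. The estimated change is an at least 1.4-fold lower number from compound 2 to compound 3 (0.15 log units; that floor lies within the scatter). For compound 3 the expected value is 3500 nM, with an estimated range of 800 nM to 10000 nM.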

Compound 3, half-maximal inhibitory concentration: > 5000 nM
Compound 3: no number, only a limit; the forecaster's own chance of this, stated with the estimate: 55%; middle value at least 1.4-fold (0.15 log units) from the limit.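

In this assay compound 3 gives > 5000 nM, a limit and not a number. For the compounds shown here, no step from compound 1 or compound 2 to compound 3 can be read. The compounds shown leave open whether the double-bond configuration or the nitrogen methyl affects inhibition at all.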